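The compounds below may be only part of what the source reports. "The series", "measured", "known", "first", "only" and "open" are said of these compounds alone.

Measured so far in an ADME assay on cells (Hepatocyte, Homo sapiens) for metabolic stability, with a stated time of 30 min (on this read-out higher numbers stand for a more stable compound and lower numbers for a less stable compound), are these compounds
- compound 1 `O=C(OC1CCC(CN2CCN(c3cc(=O)c4cc(C(F)(F)F)cc([N+](=O)[O-])c4s3)CC2)CC1)c1ccncc1` gives 1%
- compound 2 `O=c1cc(N2CCN(CC3CCCCC3)CC2)sc2c([N+](=O)[O-])cc(C(F)(F)F)cc12` gives 82.4%

Of the two, compound 2 holds the higher number, and compound 1 lies far below it. Compound 3 `CC(=O)NC1CCC(CN2CCN(c3cc(=O)c4cc(C(F)(F)F)cc([N+](=O)[O-])c4s3)CC2)CC1` is still unmeasured and differs from compound 2 in one place, on a saturated ring carbon of the six-membered non-aromatic ring of carbon only. The change there is acetamido in place of hydrogen on a saturated ring carbon and it amounts to acetamido in place of hydrogen.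

Among the measured compounds shown here, the one measured step that bears on this is a number 81.4 percentage points higher from compound 1 to compound 2 (beyond the scatter) and it comes with hydrogen in place of ((pyridin-4-yl)carbonyl)oxy on that same ring carbon. Read in reverse, this very large step links a group on that carbon with a much lower number. Acetamido is a different group, however, and a single pair cannot show how far the result carries over to it, so only part of that fall is expected. The expected step is a number 17.4 percentage points lower from compound 2 to compound 3 (beyond the scatter) and this estimate is uncertain. The estimated value for compound 3 is 65% with an expected range from 35% to 88% in this assay when it is measured.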

Compound 3, percent of the compound remaining: 86.8%
Compound 3: middle estimate off by 21.8 percentage points, on the low side, and the stated range covers the measured number.
By their numbers in this assay, from the lowest: compound 1; then compounds 2 and 3 (each within the scatter of the next).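

In this assay, acetamido in place of hydrogen on the saturated ring carbon gives a number 4.4 percentage points higher from compound 2 to compound 3 (within the scatter), so this position can carry a group of 4 heavy atoms, with a hydrogen-bond donor and acceptor, with no change beyond the scatter. The earlier pair left open whether any group on this carbon would go with a low number, and compound 3 shows that this does not hold for every group. The contrast on the same carbon, acetamido in place of ((pyridin-4-yl)carbonyl)oxy, gives a number 85.8 percentage points higher from compound 1 to compound 3 (beyond the scatter), which ties the very low number of compound 1 to that particular group, although nothing available explains why the two groups part so widely.

As far as these compounds go, with only these two groups on the ring carbon, it stays open whether the low number follows the pyridine part or the carbonyl-oxy link, which a plain acetoxy group or a (pyridin-4-yl)carbonylamino group could separate. From the compounds shown here alone, it also stays open whether an amine, a carboxylic acid or a longer chain on this carbon would stay level with acetamido or fall towards compound 1.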